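From hydroxymethyl to acetyl on the propyl-substituted core

The compounds below may be only part of what the source reports. "The series", "measured", "known", "first", "only" and "open" are said of these compounds alone.

Compound 1 `CCCn1c(=O)n(CC)c(=O)c2[nH]cnc21`: 1300 nM
Compound 2 `C=CCn1c(=O)c2[nH]cnc2n(CCC)c1=O`: 1600 nM
Compound 3 `CCCn1c(=O)n(CCCO)c(=O)c2[nH]cnc21`: 5100 nM

In a functional assay (trachea) with Cavia porcellus as the target (a lower number here means that less compound is needed, a higher number that more compound is needed for the effect), compound 3 gives 5100 nM, the highest number of the three. Its gaps to the others are both beyond the scatter: a 3.9-fold higher number from compound 1 to compound 3 (0.59 log units; beyond the scatter), and a 3.2-fold higher number from compound 2 to compound 3 (0.50 log units; beyond the scatter). The other measured step, a 1.2-fold higher number from compound 1 to compound 2 (0.09 log units; within the scatter), shows no real change between those two compounds.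

The next compound, compound 4 `CCCn1c(=O)n(CCC(C)=O)c(=O)c2[nH]cnc21`, carries acetyl in place of hydroxymethyl on a saturated chain carbon, two bonds along the chain from an aromatic nitrogen. For the measured compounds named here, no measured compound carries an acetyl, so no step speaks to it directly. The closest evidence is the step that brought hydroxymethyl in, a 3.9-fold higher number from compound 1 to compound 3 (0.59 log units; beyond the scatter). Removing that group might recover part of this modest rise, although the acetyl that enters is itself a new group, which leaves the outcome uncertain. A modest move toward a lower number in this assay is therefore expected, and the expected step is a 2.2-fold lower number from compound 3 to compound 4 (0.35 log units; beyond the scatter). For compound 4 the estimated value is 2300 nM, with an expected range from 800 nM to 6500 nM.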

Compound 4, half-maximal effective concentration: 3500 nM
Estimate against measurement, compound 4: 1.5-fold (0.18 log units) below; the range from low to high includes it.
By their numbers in this assay, from the lowest: compounds 1 and 2 (each within the scatter of the next); then compounds 4 and 3 (each within the scatter of the next).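

In this assay, acetyl in place of hydroxymethyl on a saturated chain carbon, two bonds along the chain from an aromatic nitrogen, gives a 1.5-fold lower number from compound 3 to compound 4 (0.16 log units; within the scatter), so this exchange, which removes the hydrogen-bond donor counted for hydroxymethyl, leaves the two compounds within the scatter of each other. Acetyl does not take compound 4 back to the shorter chains, as a 2.7-fold higher number from compound 1 to compound 4 (0.43 log units; beyond the scatter) and a 2.2-fold higher number from compound 2 to compound 4 (0.34 log units; beyond the scatter) show, and among the four compounds shown both the 3-hydroxypropyl and the 2-acetylethyl chain stand apart from the ethyl of compound 1 and the vinyl-bearing chain of compound 2. Nothing shown here explains why these two chains read alike or why both differ from the shorter ones.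

The compounds shown leave open whether a carboxylic acid or an amine at this place would stay with compounds 3 and 4 or depart from them, and whether a plain butyl chain, with no oxygen in it, would read like compound 4 or like compound 1. They also leave open whether the same exchange would behave alike with a cyclopropylmethyl group in place of the propyl on the shared core.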